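The source may hold more compounds than are shown below. What is called first, only, known or untested is meant among the compounds shown, and "the series" means these compounds.

Compound 1 `Cc1cc(F)cc(C)c1Oc1ccc(C(C)(C)O)cc1-c1cn(C)c(=O)c2[nH]c(C(=O)NCc3ccc(C(=O)NO)cc3)cc12`: 440 nM
Compound 2 `Cn1cc(-c2cc(C(C)(C)O)ccc2OC2CC2)c2cc(C(=O)NCCCCCCC(=O)NO)[nH]c2c1=O`: 220 nM
Compound 3 `Cn1cc(-c2cc(C(C)(C)O)ccc2OC2CC2)c2cc(C(=O)NCc3ccc(C(=O)NO)cc3)[nH]c2c1=O`: 420 nM

In a functional assay on MV4-11 cells (Homo sapiens) for antiproliferative activity, read by CCK-8 assay, with a stated time of 72 h (a lower number here means a stronger inhibitor, a higher number a weaker inhibitor), compound 3 gives 420 nM, within the scatter of both other compounds. Compound 4 `Cn1cc(-c2cc(C(C)(C)O)ccc2Oc2ccc(F)cc2F)c2cc(C(=O)NCc3ccc(C(=O)NO)cc3)[nH]c2c1=O` places 2,4-difluorophenyl in place of cyclopropyl on an oxygen on an aromatic ring. The most relevant measured change concerns the same oxygen, where swapping 4-fluoro-2,6-dimethylphenyl for cyclopropyl gave a 1.0-fold lower number from compound 1 to compound 3 (0.02 log units; within the scatter). The other change, at the hydroxycarbamoyl end, gave a 1.9-fold higher number from compound 2 to compound 3 (0.28 log units; within the scatter), and it says little about this oxygen. Neither change exceeds the scatter, so no clear shift in either direction is expected. The expected change is a 1.1-fold lower number from compound 3 to compound 4 (0.02 log units; within the scatter). For compound 4, the estimated value is 400 nM, with an expected range of 180 nM to 850 nM.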

Compound 4, half-maximal inhibitory concentration: 190 nM
The estimate for compound 4 lay 2.1-fold (0.32 log units) above the measured number; measured number inside the range.
By their numbers in this assay, from the lowest: compounds 4, 2, 3 and 1 (each within the scatter of the next, the first and the last beyond it).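

In this assay, the group on this oxygen now makes a difference: 2,4-difluorophenyl gives a 2.2-fold lower number from compound 3 to compound 4 (0.34 log units; beyond the scatter) and, set against the other aromatic group, a 2.3-fold lower number from compound 1 to compound 4 (0.36 log units; beyond the scatter) while both steps lie beyond the scatter. Earlier, cyclopropyl and 4-fluoro-2,6-dimethylphenyl could not be told apart, so an aromatic ring here does not by itself lower the number.

Still open, from the compounds shown here alone, is how an unsubstituted phenyl or a single-fluorine phenyl would compare on this oxygen, and whether 2,4-difluorophenyl would do the same alongside the 5-(hydroxycarbamoyl)pentyl chain of compound 2. No measurement shown here accounts for the difference.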